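Swapping the ortho substituent on the benzoate of a weak antagonist

The source may hold more compounds than are shown below. What is called first, only, known or untested is meant among the compounds shown, and "the series" means these compounds.

In an in vitro functional assay on HEK ts201 cells for antagonist activity at Neuronal acetylcholine receptor; alpha3/beta4 (Homo sapiens), read by fluorescence and calcium flux (on this read-out lower numbers stand for stronger inhibition and higher numbers for weaker inhibition), compound 1 `O=C(OCC1CCCN(CCCc2ccccc2)C1)c1ccccc1C(F)(F)F` gives 5500 nM; 5500 nM (2 entries). Among the compounds with values here, compound 2 `O=C(OCC1CCCN(CCCc2ccccc2)C1)c1ccccc1N1C(=O)c2ccccc2C1=O` gives 5890 nM in this assay, the only number it shows there; one further entry for compound 2 reports no single number. Compound 3 `O=C(OCC1CCCN(CCCc2ccccc2)C1)c1ccccc1-n1cc(-c2ccccc2)nn1` differs from compound 2 by a group of 11 heavy atoms (8 carbon, 3 nitrogen; one five-membered aromatic ring with 3 hetero atoms, one six-membered aromatic ring of carbon only) in place of a group of 11 heavy atoms (8 carbon, 1 nitrogen, 2 oxygen; one five-membered non-aromatic ring with 1 hetero atom, one six-membered aromatic ring of carbon only), on an aromatic carbon. Within the data shown here, no step between measured compounds is available to guide this change, so for compound 3 in this assay a shift no larger than the scatter, in either direction, is expected, a 1.0-fold higher number from compound 2 to compound 3 (0.01 log units; within the scatter). Compound 3 is accordingly estimated at 6000 nM, within a range of 2500 nM to 15000 nM.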

Compound 3, half-maximal inhibitory concentration: 4270 nM
Compound 3: middle estimate off by 1.4-fold (0.15 log units), on the high side; the measured number falls inside the stated range.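

In this assay, the exchange gives a 1.4-fold lower number from compound 2 to compound 3 (0.14 log units; within the scatter) and so sets the 4-phenyl-1H-1,2,3-triazol-1-yl group level with the group it replaces. At this aromatic carbon, ortho to a large group, a five-membered aromatic ring with 3 hetero atoms can thus stand in for a five-membered non-aromatic ring with its 2 double bonds outside aromatic rings, with no difference the read-out can resolve. Nothing available bears on this result. The compounds shown leave open whether an amine or a carboxylic acid on this aromatic carbon would give a step beyond the scatter.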